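Furan-3-yl in Place of Methyl: Expected Cytotoxicity

The source may hold more compounds than are shown below. What is called first, only, known or untested is meant among the compounds shown, and "the series" means these compounds.

Compound 1, `O=C1N(CCCCCCOc2ccc(C(F)(F)F)cc2)CCN1c1ccncc1`, gives > 25000 nM in a functional assay on cells (Homo sapiens) for cytotoxicity (on this read-out lower numbers stand for higher toxicity in this test and higher numbers for lower toxicity in this test), which is a limit of the assay and not a number.
Compound 2, `Cc1ccc(OCCCCCCN2CCN(c3ccncc3)C2=O)cc1`, gives > 25000 nM in this assay; this too is only a limit.

Compound 2 therefore stands at the limit of this assay, with no number of its own. Both measured values stand at the limit of > 25000 nM in this assay, at which 2 of the 2 values shown sit. The step that the two limits leave unreadable from compound 1 to compound 2 cannot be sized because both compounds sit at the limit of > 25000 nM in this assay, at which 2 of the 2 values shown sit. Compound 3, `O=C1N(CCCCCCOc2ccc(-c3ccoc3)cc2)CCN1c1ccncc1`, differs from compound 2 by furan-3-yl in place of methyl on an aromatic carbon. Among the compounds with values here, no measured step bears on this change with a readable size. Compound 3 is expected to remain at the limit as well, with the step that the limit leaves unreadable from compound 2 to compound 3 expected to stay within the scatter. The estimate for compound 3 is 30000 nM, from 12000 nM to 80000 nM.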

Compound 3, half-maximal cytotoxic concentration: > 25000 nM
Compound 3: a limit, no number (the forecaster's own chance of this, stated with the estimate: 75%); the middle value does not contradict the limit.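

No step can be read among compound 1, compound 2 and compound 3, because all three give only a limit and no number: the limit of > 25000 nM in this assay, at which 3 of the 3 values shown sit.

The compounds shown leave open whether trifluoromethyl, methyl and furan-3-yl differ at all in this assay.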